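This account rests on a few compounds, and the source may have more. Where it says the series, first, only, none or still open, it means among the compounds named here.

Working notes on the series. In a functional assay on XF498 cells (Homo sapiens) for cytotoxicity (on this read-out higher numbers stand for weaker inhibition and lower numbers for stronger inhibition), compound 2 (`COc1ccc(-c2cc3c(N(C)C)cccc3c(N3CCN(C)CC3)n2)cc1`) gives 10700 nM and stands level with compound 1 (`CN1CCN(c2nc(-c3ccc(Cl)cc3)cc3c(N(C)C)cccc23)CC1`), which gives 7300 nM in the same test. For the measured compounds named here, these two numbers lie within the scatter of each other, and no third measured compound is available to place them against.

Compound 3 (`CN1CCN(c2nc(-c3ccccc3)cc3c(N(C)C)cccc23)CC1`) differs from compound 2 by a single change (hydrogen in place of methoxy on an aromatic carbon): hydrogen in place of methoxy on an aromatic carbon, para to a large group, so that 4-methoxyphenyl becomes phenyl.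

Going by the values given here, one measured step bears on this change: methoxy in place of chloro on an aromatic carbon, which gave a 1.5-fold higher number from compound 1 to compound 2 (0.17 log units; within the scatter) and stayed within the scatter. Among the compounds with values here, no measured compound carries hydrogen at this carbon, so the data leave the unsubstituted phenyl untested, and a single step shows no trend. Within the data shown here, with a 1.5-fold higher number from compound 1 to compound 2 (0.17 log units; within the scatter) as the only guide, no shift beyond the scatter is expected in this assay, and no direction is favoured. The expected step, a 1.2-fold lower number from compound 2 to compound 3 (0.08 log units; within the scatter) in this test, is correspondingly small. For compound 3 the estimated value is 9000 nM with an expected range from 4500 nM to 18000 nM in this test.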

Compound 3, half-maximal inhibitory concentration: 9550 nM
Compound 3: middle estimate off by 1.1-fold (0.03 log units), on the low side, within the range that was stated.
By their numbers in this assay, from the lowest: compounds 1, 3 and 2 (each within the scatter of the next).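

Hydrogen on this aromatic carbon, para to a large group, gives a 1.1-fold lower number from compound 2 to compound 3 (0.05 log units; within the scatter), and in place of chloro it gives a 1.3-fold higher number from compound 1 to compound 3 (0.12 log units; within the scatter). For the compounds shown here, the unsubstituted phenyl of compound 3 therefore stands level with both substituted compounds in this assay, so that across hydrogen, chloro and methoxy at this carbon, no step leaves the scatter; with only the chloro-to-methoxy step available earlier, this was not yet visible. No supporting evidence is available to explain this flat result.

As far as these compounds go, these three groups at one carbon span too little to show whether this position can affect the read-out at all, and whether an amine, a carboxylic acid or a longer alkoxy chain in their place would give a step beyond the scatter remains open. Also open, from the compounds shown here alone, is whether the same flat result would hold with other parts of the shared core altered, since all three compounds differ only at this one carbon.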